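The source may hold more compounds than are shown below. What is called first, only, known or untested is meant among the compounds shown, and "the series" means these compounds.

In an ADME assay on HepG2 cells (Homo sapiens) for cytotoxicity, read by MTT assay, with a stated time of 72 h (on this read-out higher numbers stand for lower toxicity in this test and lower numbers for higher toxicity in this test), compound 1 (`O=[N+]([O-])c1c(CS(=O)(=O)c2ccccc2)nc2c(-c3ccccc3)cc(Cl)cn12`) gives > 15600 nM as its reading, which is a limit and not a number. Compound 2 (`O=[N+]([O-])c1c(CS(=O)(=O)c2ccccc2)nc2c(-c3ccc(Cl)cc3)cc(Cl)cn12`) gives > 3900 nM as well, again a limit. Compound 3 (`O=[N+]([O-])c1c(CS(=O)(=O)c2ccccc2)nc2c(-c3ccc(CO)cc3)cc(Cl)cn12`) reads 13100 nM and is the only one of the three with a true number.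

Compound 4 (`O=[N+]([O-])c1c(CS(=O)(=O)c2ccccc2)nc2c(-c3cccc(CO)c3)cc(Cl)cn12`) has not been measured yet. Its change from compound 1 is hydroxymethyl in place of hydrogen on an aromatic carbon and the new group stands meta to a large group.

Compound 3 carries the same kind of exchange, so its step is the useful guide (an at least 1.1-fold lower number from compound 1 to compound 3 (0.07 log units; that floor lies within the scatter)) although that figure is only a floor. The two steps involving the chloro group cannot be sized (a step that the two limits leave unreadable from compound 1 to compound 2 and a step that the limit leaves unreadable from compound 2 to compound 3) and so add nothing to the forecast.

Going by compound 3 with its reading of 13100 nM as the one real number nearby, a small step or none beyond the scatter is expected in this assay for this change (an at least 1.1-fold lower number from compound 1 to compound 4 (0.04 log units; that floor lies within the scatter)). Compound 4 may again give only a limit in this assay.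

For compound 4 the estimated value is 14000 nM with 7000 nM to 28000 nM as the expected range.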

Compound 4, half-maximal cytotoxic concentration: > 25000 nM
Compound 4: a limit, no number; the forecaster's own chance of this, stated with the estimate: 35%; middle value at least 1.7-fold (0.25 log units) away from the limit.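

In this assay, among the compounds shown here, the exchange of 4-(hydroxymethyl)phenyl for 3-(hydroxymethyl)phenyl allows the first comparison between two placements of the hydroxymethyl group, and it gives an at least 1.9-fold higher number from compound 3 to compound 4 (0.28 log units; that floor lies within the scatter). That figure is only a floor, so the true gap could be small or considerably larger, and these compounds do not establish that the placement matters. The new placement, meta to a large group, leaves compound 4 with a limit and not a number, and its steps from compound 1 and from compound 2 cannot be read: the limit of > 25000 nM in this assay, at which 1 of the 4 values shown sits.

On these data alone, whether adding hydroxymethyl to the phenyl ring changes the reading at all stays open, since compound 1 and compound 4 both lack a true number for comparison. Also open, as far as these compounds go, is how an amine, a carboxylic acid or a longer chain such as hydroxyethyl would read at this same place on the ring, and whether any of them would give a true number in this assay.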